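Changing the Group on the Ring Amine Nitrogen

The source may hold more compounds than are shown below. What is called first, only, known or untested is meant among the compounds shown, and "the series" means these compounds.

Compound 1: `CCCc1nc(-c2ccccc2)c(CNCCN2CCN(c3cccc(C)c3)CC2)o1`, 43.1%
Compound 2: `CCCc1nc(-c2ccccc2)c(CNCCCN2CCN(c3ccc(OC)cc3)CC2)o1`, 42.1%

Both compounds were tested in an assay on HEK293 cells for inhibition of Voltage-dependent T-type calcium channel subunit alpha-1G (Homo sapiens), read by fluorescence, tested at 10 uM; on this read-out higher numbers stand for more inhibition at the one concentration tested (going by the name of the read-out) and lower numbers for less inhibition. Compound 2 and compound 1 give numbers that lie within the usual scatter of one another, so the two cannot be told apart on this read-out; compound 2 simply sits at the same level as compound 1.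

Compound 3 is `CCCc1nc(-c2ccccc2)c(CNCCCN2CCN(c3ccc(C)c(C)c3)CC2)o1`. It differs from compound 2 in one place: 3,4-dimethylphenyl in place of 4-methoxyphenyl on an amine nitrogen in a ring. Among the measured compounds shown here, no pair of measured compounds isolates this change, so its effect is not known. Compound 1 carries a methyl-bearing ring on that nitrogen, but it also differs from compound 2 in its linker, so its value only shows that such a ring can land near the level of compound 2.

The step of a number 2.9 percentage points higher from compound 2 to compound 3 (within the scatter) is therefore expected to stay within the scatter. Compound 3 is estimated at 45%, with a range from 25% to 65%.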

Compound 3, a percentage reported as inhibition, at one concentration (the size of the read-out at that concentration, not a potency): 54.6%
Estimate against measurement, compound 3: 9.6 percentage points below, within the range that was stated.
By their numbers in this assay, from the lowest: compounds 2 and 1 (each within the scatter of the next); then compound 3.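

In this assay the change from 4-methoxyphenyl to 3,4-dimethylphenyl on the amine nitrogen in the ring gives a number 12.5 percentage points higher from compound 2 to compound 3 (beyond the scatter) with the rest of the molecule unchanged. Among the compounds shown here, this is the first pair that isolates this position, and it shows that the group carried there can move the read-out by more than the scatter. The group that leaves holds an oxygen and a hydrogen-bond acceptor while the group that enters holds only carbon, but one pair cannot show which of these differences matters.

As far as these compounds go, it remains open whether a single methyl group on the phenyl ring would match the two in compound 3, and how a 4-chlorophenyl or a pyridine ring on that nitrogen would compare. From the compounds shown here alone, it is also open whether the step would hold with the linker of compound 1. No measurement here bears on why the number rises.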